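The source may hold more compounds than are shown below. What is called first, only, known or untested is meant among the compounds shown, and "the series" means these compounds.

Measured compounds:
compound 1, `Cc1ccc(NC(=O)NN=C2CCCCC2)cc1` — 300 mg/kg
compound 2, `O=C(N/N=C/c1ccc(O)cc1)Nc1ccccc1Cl` — 100 mg/kg
compound 3, `COc1ccc(/C(C)=N/NC(=O)Nc2ccccc2Cl)cc1` — 300 mg/kg

In a functional assay on the whole organism with Mus musculus as the target, with a stated time of 4 h (a higher number here means that more compound is needed for the effect, a lower number that less compound is needed), compound 3 gives 300 mg/kg, level with compound 1 at the digits shown, and these two stand together as the highest numbers of the three. Within the data shown here, compound 2 gives 100 mg/kg, a lower number, and that gap lies beyond the scatter; no single-point step connects compound 2 to either of the other two, so only the two values themselves can be read.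

Compound 4, `C/C(=N\NC(=O)Nc1ccccc1Cl)c1ccc(Cl)cc1`, differs from compound 3 in one place: chloro in place of methoxy on an aromatic carbon. Among the measured compounds shown here, no measured pair shows this same change, so there is no step to lean on. Without such a precedent, the expectation is a step from compound 3 to compound 4 of no change at the digits printed from compound 3 to compound 4 (within the scatter), that is, no shift beyond the scatter in either direction. Compound 4 is therefore estimated at 300 mg/kg in this assay, with a range from 100 mg/kg to 1000 mg/kg.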

Compound 4, minimum effective dose: 100 mg/kg
Beside the measured number, compound 4's estimate is 3.0-fold (0.48 log units) above it, and the stated range covers the measured number.
By their numbers in this assay, from the lowest: compounds 2 and 4 (each within the scatter of the next); then compounds 1 and 3 (each within the scatter of the next).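

In this assay, the series gains its first step at a single position: chloro in place of methoxy, on an aromatic carbon para to a large group, gives a 3.0-fold lower number from compound 3 to compound 4 (0.48 log units; beyond the scatter). The earlier compounds shown here, linked by no single-place step, could not show that the number responds to the group at this position, and this pair shows that it does, beyond the scatter. No measurement bearing on the reason for this step is available, so the observation stands without an explanation.

On these data alone, the change rests on one pair, so it remains open whether chloro in place of methoxy gives a similar step on other parts of the series. Also open, as far as these compounds go, is how an amine or a nitrile at this position would compare with chloro and methoxy.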